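The source may hold more compounds than are shown below. What is called first, only, known or untested is meant among the compounds shown, and "the series" means these compounds.

In a functional assay on the whole organism (Pleural cavity) with Rattus norvegicus as the target (on this read-out lower numbers stand for an effect already at smaller amounts and higher numbers for an effect only at larger amounts of compound), compound 1 `[O-][n+]1ccc2[nH]cnc2c1` reaches only a limit of the assay, giving > 9 mg/kg. Compound 2 `OC[C@H]1O[C@@H](n2cnc3c(NCc4ccccc4)nccc32)C[C@@H]1O` likewise gives only a limit in this assay, namely > 9 mg/kg. Both values shown therefore sit at the limit of > 9 mg/kg in this assay, at which 2 of the 2 values shown sit, and compound 2 stands at that limit together with the other value. Compound 3 `OC[C@H]1O[C@@H](n2cnc3cnccc32)C[C@@H]1O` has not yet been measured in this assay; it differs from compound 2 by hydrogen in place of benzylamino on an aromatic carbon. Among the compounds with values here, with no measured step to draw on, no change beyond the scatter is expected, and the step is estimated at a step that the limit leaves unreadable from compound 2 to compound 3. Compound 3 is thus expected to give about 15 mg/kg, within a range from 5 mg/kg to 50 mg/kg.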

Compound 3, dose for half-maximal effect: > 9 mg/kg
Compound 3: a limit, no number (the forecaster's own chance of this, stated with the estimate: 75%); the middle value does not contradict the limit.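

Compound 2 and compound 3 both give only a limit in this assay, so the step between them cannot be read. The compounds shown leave open whether hydrogen in place of benzylamino changes the dose for half-maximal effect at all.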